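Bromo for Dimethylamino: Cytotoxicity on Vero Cells

The source may hold more compounds than are shown below. What is called first, only, known or untested is meant among the compounds shown, and "the series" means these compounds.

Compound 1, `COc1nc(C)nc(/N=C/c2ccc(N(C)C)cc2)n1`: > 50 ug/mL
Compound 2, `COc1nc(C)nc(/N=C/c2ccc(Cl)cc2Cl)n1`: > 50 ug/mL

The two measured compounds share a core and differ only in the aromatic ring hanging from the imine. In an ADME assay on Vero cells (Chlorocebus sabaeus) for cytotoxicity, read by MTT assay, with a stated time of 72 h (on this read-out lower numbers stand for stronger inhibition and higher numbers for weaker inhibition), compound 1 gives > 50 ug/mL, which is a limit of the assay rather than a number. Compound 2 gives > 50 ug/mL in this assay, again a limit. Every value seen so far therefore sits at the limit of > 50 ug/mL in this assay, at which 2 of the 2 values shown sit. Within the data shown here, no step between measured compounds can be read, because nothing is known beyond these limits.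

Compound 3, `COc1nc(C)nc(/N=C/c2ccc(Br)cc2)n1`, has not yet been measured. It differs from compound 1 by bromo in place of dimethylamino on an aromatic carbon. Since both measured compounds, with quite different groups on that ring, stay at the limit, the change from compound 1 to compound 3 is expected to bring no step beyond the scatter in this assay. The expected step is a step that the limit leaves unreadable from compound 1 to compound 3. Compound 3 is expected to give about 60 ug/mL, within a range from 30 ug/mL to 150 ug/mL, and most likely to be reported only as a limit again.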

Compound 3, half-maximal inhibitory concentration: > 50 ug/mL
Compound 3: a limit, no number; the forecaster's own chance of this, stated with the estimate: 80%; the middle value is on the limit's open side.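

In this assay compound 3 also gives only a limit, like compound 1 and compound 2, so no step from compound 1 to compound 3 can be read: the limit of > 50 ug/mL in this assay, at which 3 of the 3 values shown sit.

The compounds shown leave open how far past that limit each one lies, and whether bromo in place of dimethylamino changes cytotoxicity at all.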